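Iodo in place of fluoro on the thiourea aryl of compound 3

The compounds below may be only part of what the source reports. "The series", "measured", "known", "first", "only" and "open" are said of these compounds alone.

Compound 1, `N#Cc1ccccc1CN1CCc2c(sc(NC(=O)c3ccccc3Cl)c2C(N)=O)C1`: 9500 nM
Compound 2, `NC(=O)c1c(NC(=O)c2ccccc2Cl)sc2c1CCN(C(=S)Nc1cccc3ccccc13)C2`: 20700 nM
Compound 3, `NC(=O)c1c(NC(=O)c2ccccc2Cl)sc2c1CCN(C(=S)Nc1ccccc1F)C2`: 12600 nM

In a functional assay on MKN-74 cells (Homo sapiens) for antiproliferative activity, with a stated time of 24 h (a higher number here means a weaker inhibitor, a lower number a stronger inhibitor), compound 3 gives 12600 nM, the second highest of the three numbers. Its nearest neighbour is compound 1, with a 1.3-fold higher number from compound 1 to compound 3 (0.12 log units; within the scatter); the furthest is compound 2, with a 1.6-fold lower number from compound 2 to compound 3 (0.22 log units; within the scatter), so all three values sit within the scatter of one another. Compound 4, `NC(=O)c1c(NC(=O)c2ccccc2Cl)sc2c1CCN(C(=S)Nc1ccccc1I)C2`, differs from compound 3 by iodo in place of fluoro on an aromatic carbon. Among the measured compounds shown here, no measured step exchanges one halogen for another on this ring; the only step touching the same aryl, from a naphthyl to a fluorophenyl, stayed within the scatter. A step beyond the scatter is therefore not expected in this assay. For compound 4 the expected value is 12000 nM, with a range from 5000 nM to 30000 nM. The expected step is a 1.1-fold lower number from compound 3 to compound 4 (0.02 log units; within the scatter), within the scatter.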

Compound 4, half-maximal inhibitory concentration: 2630 nM
Estimate against measurement, compound 4: 4.6-fold (0.66 log units) above, and the stated range ends above it.
By their numbers in this assay, from the lowest: compound 4; then compounds 1, 3 and 2 (each within the scatter of the next, the first and the last beyond it).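

In this assay, the halogen on this aryl ring proves to matter: iodo in place of fluoro gives a 4.8-fold lower number from compound 3 to compound 4 (0.68 log units; beyond the scatter), although only one heavy atom is exchanged for another. Among the compounds shown here, the steps of a 7.9-fold lower number from compound 2 to compound 4 (0.90 log units; beyond the scatter) and a 3.6-fold lower number from compound 1 to compound 4 (0.56 log units; beyond the scatter) also lie beyond the scatter, making compound 4 the strongest of the four, whereas the earlier compounds stayed within the scatter of one another. Nothing shown here accounts for this gain.

As far as these compounds go, it remains open whether chloro or bromo at this place would give a step of similar size. Whether a methyl or methoxy group could match iodo also stays unanswered.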